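Trimming the tert-butyl: from compound 1 to compound 4

The source may hold more compounds than are shown below. What is called first, only, known or untested is meant among the compounds shown, and "the series" means these compounds.

Compound 1 `CC(C)(C)c1nnc2nnc(N3CCCC3)nn12` is one of three compounds with a shared core that have been tested in a functional assay on HL-60 cells (Homo sapiens) for cytotoxicity, read by MTT assay, with a stated time of 72 h; a higher number here means a weaker inhibitor, a lower number a stronger inhibitor. In this assay compound 1 gives > 100000 nM, which is a limit of the assay rather than a number. Compound 2 `c1ccc(-c2nnc3nnc(N4CCCC4)n3n2)cc1` gives > 100000 nM in this assay, also a limit. Compound 3 `O=[N+]([O-])c1ccc(-c2nnc3nnc(N4CCCC4)n3n2)cc1` gives > 100000 nM in this assay, again a limit. For the measured compounds named here, the only step between measured compounds, a step that the two limits leave unreadable from compound 2 to compound 3, therefore cannot be read, and all three values sit at the limit of > 100000 nM in this assay, at which 3 of the 3 values shown sit. Compound 4 `CC(C)c1nnc2nnc(N3CCCC3)nn12` differs from compound 1 by hydrogen in place of methyl on a saturated chain carbon bound to an aromatic carbon and two saturated chain carbons, a tert-butyl cut to an isopropyl. Going by the values given here, no measured step bears directly on this change, and the one recorded step concerns an aromatic substituent and is itself unreadable. Because every known value sits at the limit of > 100000 nM in this assay, at which 3 of the 3 values shown sit, no movement beyond the scatter is expected from this change. The expected step is a step that the limit leaves unreadable from compound 1 to compound 4. Compound 4 is therefore expected to give about 200000 nM in this assay, with a range from 50000 nM to 1000000 nM, most likely reported again as a limit.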

Compound 4, half-maximal inhibitory concentration: 71200 nM
Compound 4: middle estimate off by 2.8-fold (0.45 log units), on the high side, within the range that was stated.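

In this assay compound 4 gives 71200 nM, the only number among the compounds shown that is not a limit, so this position is the first place where the series yields a readable value. The change from tert-butyl to isopropyl amounts to an at least 1.4-fold lower number from compound 1 to compound 4 (0.14 log units; that floor lies within the scatter); only a floor is known for this step, and that floor does not establish a change beyond the scatter. The one earlier step cannot be read, and most of the series remains at the ceiling: the limit of > 100000 nM in this assay, at which 3 of the 4 values shown sit.

On these data alone, whether an ethyl, a methyl, an amine or a carboxylic acid in place of the isopropyl would carry the number lower stays open. As far as these compounds go, the full size of the step also stays open, as the value for compound 1 is a limit and not a number.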